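Swapping cyclohexyl for 2-fluorophenyl on the amide nitrogen

The compounds below may be only part of what the source reports. "The series", "measured", "known", "first", "only" and "open" are said of these compounds alone.

For the measured compounds named here, compound 2 `O=C(CN1CCC(c2cccc[n+]2[O-])CC1)NC1CCCCC1` gives 294 nM in a functional assay on HEK293 cells for agonist activity at D(4) dopamine receptor (Homo sapiens), read by FLIPR (on this read-out lower numbers stand for an effect already at smaller amounts and higher numbers for an effect only at larger amounts of compound), the higher of the two numbers known so far; compound 1 `O=C(CN1CCC(c2cccc[n+]2[O-])CC1)Nc1cccc(F)c1` gives 160 nM in this assay. Compound 3 `O=C(CN1CCC(c2cccc[n+]2[O-])CC1)Nc1ccccc1F` differs from compound 2 by 2-fluorophenyl in place of cyclohexyl on an amide-type nitrogen. Going by the values given here, the only step that bears on this is a 1.8-fold higher number from compound 1 to compound 2 (0.26 log units; within the scatter), which runs the other way between an aryl and a cyclohexyl group. Compound 3 is therefore expected to show a 1.6-fold lower number from compound 2 to compound 3 (0.21 log units; within the scatter), nothing beyond the scatter. Compound 3 is estimated at 180 nM, within a range from 70 nM to 450 nM.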

Compound 3, half-maximal effective concentration: 270 nM
Beside the measured number, compound 3's estimate is 1.5-fold (0.18 log units) below it, within the range that was stated.
By their numbers in this assay, from the lowest: compounds 1, 3 and 2 (each within the scatter of the next).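

In this assay, 2-fluorophenyl in place of cyclohexyl on the amide-type nitrogen gives a 1.1-fold lower number from compound 2 to compound 3 (0.04 log units; within the scatter) and so leaves the read-out within the scatter, whether the six-membered ring of carbon only is aromatic or not. 2-Fluorophenyl in place of 3-fluorophenyl gives a 1.7-fold higher number from compound 1 to compound 3 (0.23 log units; within the scatter) and is also within the scatter, so these compounds show no effect of where the fluorine sits. Nothing measured here accounts for these groups reading alike. Open, on these data alone, is whether unsubstituted phenyl, a longer chain, an amine or a carboxylic acid on this nitrogen would read alike too.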